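The source may report more compounds than this note shows. Statements on the series, on what has been measured and on what is new or still open speak of the compounds shown alone.

Compound 1 `COc1ccc(C2CC(C3C(=O)c4ccccc4C3=O)=NC(=O)N2)cc1`: 10%
Compound 2 `O=C1N=C(C2C(=O)c3ccccc3C2=O)CC(c2cccc([N+](=O)[O-])c2)N1`: 12%
Compound 3 `O=C1N=C(C2C(=O)c3ccccc3C2=O)CC(c2ccc(Cl)cc2)N1`: 34%

Of the compounds shown here, three have been tested in a functional assay on the whole organism for inhibition, with Rattus norvegicus as the target, read by paw edema, with stated times of 30 min and 4 h, at a dose of 10 mg/kg by the oral route; a lower number here means less inhibition, a higher number more inhibition at the dose given (going by the name of the read-out). Compound 3 stands highest of the three: the change of a number 22 percentage points higher from compound 2 to compound 3 (beyond the scatter) and that of a number 24 percentage points higher from compound 1 to compound 3 (beyond the scatter) are both beyond the scatter, while a number 2 percentage points higher from compound 1 to compound 2 (within the scatter) is not, so compound 1 and compound 2 cannot be set in order against each other.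

Compound 4 `CN(C)c1ccc(C2CC(C3C(=O)c4ccccc4C3=O)=NC(=O)N2)cc1` differs from compound 3 by dimethylamino in place of chloro on an aromatic carbon. The step that bears on this most directly is a number 24 percentage points higher from compound 1 to compound 3 (beyond the scatter), in which the group on the same aromatic carbon was exchanged, chloro in place of methoxy, and the number rose modestly. Among the compounds with values here, compound 4 now replaces that chloro with a group that was not present in any measured compound, so no step shows its effect directly. Within the data shown here, with the only known change at this position being the gain from methoxy to chloro, a move away from chloro is expected to undo a gain of about that size, giving in this assay a number 19 percentage points lower from compound 3 to compound 4 (beyond the scatter). Compound 4 is therefore estimated at 15%, with a range from 5% to 30%.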

Compound 4, a percentage reported as inhibition, in the whole organism at one dose (the size of the read-out at that dose, not a potency): 16%
Estimate against measurement, compound 4: 1 percentage points below; low and high end bracket the measured number.
By their numbers in this assay, from the lowest: compounds 1, 2 and 4 (each within the scatter of the next); then compound 3.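

In this assay, putting dimethylamino in place of chloro on the aromatic carbon para to a large group gives a number 18 percentage points lower from compound 3 to compound 4 (beyond the scatter), so chloro now stands apart from two other groups at this same carbon, not only from methoxy. Dimethylamino in place of methoxy gives a number 6 percentage points higher from compound 1 to compound 4 (within the scatter), and 4-(dimethylamino)phenyl in place of 3-nitrophenyl gives a number 4 percentage points higher from compound 2 to compound 4 (within the scatter), so neither step separates compound 4 from the compound it is compared with, and of the groups shown only chloro goes with the higher number. The data shown offer no measurement that could explain why chloro stands apart at this position.

The compounds shown leave open whether bromo or fluoro on this same carbon would hold the number of compound 3 or fall back to the level of the other three, and where a plain hydrogen there would stand. They also leave open how a methyl group or a carboxylic acid at this carbon would read in this assay, and whether the gap seen with chloro would persist at other doses.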